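Series notes: replacing the phenyl on compound 2

A few compounds are considered here, and "the series" means these few. Any claim that something is new, unique, unknown or untested is made for them only; others in the source may bear on it.

Measured so far:
compound 1 `CCOc1cc(NC(=O)C2(NC(=O)c3ccc4c(C5CCCC5)c(-c5ncc(Cl)cn5)n(C)c4c3)CCC2)ccc1/C=C/C(=O)OCOP(=O)(O)OC(C)(C)C` — in an ADME assay (liver) for pharmacokinetics, with Liver microsome (Rattus norvegicus) as the target, using microsomes (on this read-out lower numbers stand for a shorter-lived compound and higher numbers for a longer-lived compound), compound 1 gives 0.133 h
compound 2 `CCOc1cc(NC(=O)C2(NC(=O)c3ccc4c(C5CCCC5)c(-c5ncc(Cl)cn5)n(C)c4c3)CCC2)ccc1/C=C/C(=O)OCCOc1ccccc1` — in this assay compound 2 gives 16.5 h

Among the compounds with values here, compound 2 stands highest of the two numbers in this assay; its nearest neighbour is compound 1, and the only measured step, a 120-fold higher number from compound 1 to compound 2 (2.09 log units; beyond the scatter), is large and beyond the scatter. Within the data shown here, that step swaps a nine-atom chain for a phenoxyethyl group on the saturated chain carbon bound to an oxygen next to a carbonyl, and it is the sole guide available.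

Compound 3 `CCOc1cc(NC(=O)C2(NC(=O)c3ccc4c(C5CCCC5)c(-c5ncc(Cl)cn5)n(C)c4c3)CCC2)ccc1/C=C/C(=O)OCCOCCOC` differs from compound 2 by 2-methoxyethyl in place of phenyl on an oxygen on a saturated carbon. Among the measured compounds shown here, no measured step matches this exchange; the one on hand concerns a different place and a different pair of groups, so it bears on compound 3 only in showing that changes in this region of the molecule can move this assay strongly. Direction for compound 3 is therefore open, and the estimated step of a 2.8-fold lower number from compound 2 to compound 3 (0.44 log units; beyond the scatter) is taken as a moderate decrease with a wide range. For compound 3 the expected value is 6 h, between 1.5 h and 20 h.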

Compound 3, half-life: 1.07 h
Compound 3: middle estimate off by 5.6-fold (0.75 log units), on the high side; measured number below the stated range.
By their numbers in this assay, from the lowest: compound 1; then compound 3; then compound 2.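

At the oxygen on a saturated carbon, 2-methoxyethyl in place of phenyl gives a 15-fold lower number from compound 2 to compound 3 (1.19 log units; beyond the scatter) in this assay, so the end group alone, with the rest of the molecule unchanged, moves this read-out strongly. Within the data shown here, the open-chain group of compound 3 still keeps part of the gain over the phosphorus-bearing group, with an 8.0-fold higher number from compound 1 to compound 3 (0.91 log units; beyond the scatter), which places it between the other two, and the one group with an aromatic ring holds the highest number of the three. Nothing at hand explains the size of either step.

Open, on these data alone, is whether the number follows the aromatic ring as such or some other feature of the end group; a cyclohexyl group on the same oxygen would separate these. Equally open, as far as these compounds go, is how a pyridyl ring or a shorter chain such as ethyl would read there.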